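Compound 2 to compound 4: a new nitrogen substituent

The source may hold more compounds than are shown below. What is called first, only, known or untested is meant among the compounds shown, and "the series" means these compounds.

For the measured compounds named here, in an ADME assay on A549 cells (Homo sapiens) for cytotoxicity, read by resazurin assay, with a stated time of 48 h (a lower number here means that less compound is tolerated, a higher number that more compound is tolerated), compound 2 (`CC1(Nc2ccc(NC(=O)c3cc(Cl)ccc3O)c(Cl)c2)CCCC1`) gives 157000 nM, the highest of the three numbers measured so far. Compound 1 (`O=C(Nc1ccc(NCC2CC2)cc1Cl)c1cc(Cl)ccc1O`) gives 14400 nM and compound 3 (`CC1(ON(c2ccc(NC(=O)c3cc(Cl)ccc3O)c(Cl)c2)C2(C)CCCC2)CCCC1`) gives 18000 nM, both lower than compound 2 by more than the scatter.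

The next compound is compound 4 (`COc1ccc(CNc2ccc(NC(=O)c3cc(Cl)ccc3O)c(Cl)c2)cc1`), with 4-methoxybenzyl in place of 1-methylcyclopentyl on a nitrogen on an aromatic ring.

Going by the values given here, two measured steps bear on this change. The large one is an 11-fold higher number from compound 1 to compound 2 (1.04 log units; beyond the scatter), with 1-methylcyclopentyl in place of cyclopropylmethyl on the same nitrogen. The modest one is an 8.7-fold lower number from compound 2 to compound 3 (0.94 log units; beyond the scatter), with (1-methylcyclopentyl)oxy in place of hydrogen on that nitrogen. Both show the number moving with the substitution on this nitrogen, and compound 2 stands highest. Structurally, 4-methoxybenzyl reads closer to cyclopropylmethyl than to 1-methylcyclopentyl, so compound 1 at 14400 nM is taken as the nearer guide. Among the compounds with values here, no measured compound carries an aromatic ring in this group, which leaves the size of the step uncertain.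

A lower number, beyond the scatter, is expected, with an estimated step of a 7.9-fold lower number from compound 2 to compound 4 (0.89 log units; beyond the scatter). For compound 4 the estimated value is 20000 nM, with an expected range of 6000 nM to 70000 nM.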

Compound 4, half-maximal cytotoxic concentration: 80700 nM
Beside the measured number, compound 4's estimate is 4.0-fold (0.61 log units) below it; measured number above the stated range.
By their numbers in this assay, from the lowest: compounds 1 and 3 (each within the scatter of the next); then compounds 4 and 2 (each within the scatter of the next).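

In this assay, replacing 1-methylcyclopentyl with 4-methoxybenzyl on this nitrogen gives a 1.9-fold lower number from compound 2 to compound 4 (0.29 log units; within the scatter), so the two groups are not told apart here, even though one carries a five-membered non-aromatic ring and the other a six-membered aromatic ring and a hydrogen-bond acceptor. Replacing the cyclopropyl of the cyclopropylmethyl group with 4-methoxyphenyl gives a 5.6-fold higher number from compound 1 to compound 4 (0.75 log units; beyond the scatter), which leaves compound 1 apart from both compound 2 and compound 4 among the compounds with a single carbon substituent on this nitrogen, and shows that the higher number at this position is not confined to the 1-methylcyclopentyl group. No measurement of a property of these groups accompanies the numbers, and no explanation for this pattern can be offered.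

The compounds shown do not separate the contribution of the methoxy from that of the benzyl ring, and a plain benzyl or a benzyl bearing a carboxylic acid would address that question. They also leave open whether a (1-methylcyclopentyl)oxy group on the nitrogen of compound 4 would repeat an 8.7-fold lower number from compound 2 to compound 3 (0.94 log units; beyond the scatter) on this different substituent.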